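Nitro for Chloro on the Anilide: Cytotoxicity Outlook

This account rests on a few compounds, and the source may have more. Where it says the series, first, only, none or still open, it means among the compounds named here.

Compound 2, `COc1ccc(-n2ccnc2SCC(=O)Nc2ccccc2Cl)cc1`, carries a chloro group on an aromatic carbon of its anilide ring. In an ADME assay on MT4 cells (Homo sapiens) for cytotoxicity, read by MTT assay (on this read-out lower numbers stand for higher toxicity in this test and higher numbers for lower toxicity in this test), compound 2 gives only a limit, > 334000 nM. Compound 1, `COc1ccc(-n2ccnc2SCC(=O)Nc2ccccc2Br)cc1`, has a bromo group in the same place. In this assay compound 1 also reaches only a limit, > 298000 nM. The step that the two limits leave unreadable from compound 1 to compound 2 cannot be read, since both ends sit at limits (the limit of > 298000 nM in this assay, at which 1 of the 2 values shown sits, and (the limit of > 334000 nM in this assay, at which 1 of the 2 values shown sits)).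

Compound 3, `COc1ccc(-n2ccnc2SCC(=O)Nc2ccccc2[N+](=O)[O-])cc1`, differs from compound 2 by nitro in place of chloro on an aromatic carbon: a nitro in place of chloro on an aromatic carbon, ortho to a large group, so that 2-chlorophenyl becomes 2-nitrophenyl. Within the data shown here, the only measured step concerns a different exchange at this position and is itself unreadable, so no measured step bears directly on this change, and nothing on hand points to a step beyond the scatter in either direction. Compound 3 is therefore expected to behave like compound 2 in this assay, most likely again reaching only a limit, with an estimated value of 300000 nM, between 100000 nM and 700000 nM. The step of an at least 1.1-fold lower number from compound 2 to compound 3 (0.04 log units; that floor lies within the scatter) is estimated to stay within the scatter.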

Compound 3, half-maximal cytotoxic concentration: 161000 nM
Beside the measured number, compound 3's estimate is 1.9-fold (0.27 log units) above it, within the range that was stated.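

Among these compounds, compound 3 is the first compound here to give a number rather than a limit in this assay, so this position can now register a change: nitro in place of chloro gives an at least 2.0-fold lower number from compound 2 to compound 3 (0.31 log units; beyond the scatter), while nitro in place of bromo gives an at least 1.8-fold lower number from compound 1 to compound 3 (0.26 log units; that floor lies within the scatter). As far as these compounds go, the step from the chloro compound is a true floor, and its true size stays unknown, because compound 2 stands at a limit: the limit of > 334000 nM in this assay, at which 1 of the 3 values shown sits. The step from the bromo compound is likewise only a floor, because compound 1 stands at a limit: the limit of > 298000 nM in this assay, at which 1 of the 3 values shown sits.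

The step between the bromo and chloro compounds still cannot be read, so the two halogens cannot be ranked against each other, and how far either lies from the nitro compound remains unsettled. The compounds shown also leave open whether an amine or a carboxylic acid on the same aromatic carbon would give a number like that of compound 3 or return to a limit.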